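A few compounds are considered here, and "the series" means these few. Any claim that something is new, unique, unknown or untested is made for them only; others in the source may bear on it.

Measured so far:
compound 1 `Cc1ccc(-c2cn(/N=C/c3cc4ccccc4nc3Cl)c(N)n2)cc1` — > 50000 nM
compound 2 `COc1ccc(-c2cn(/N=C/c3cc4ccccc4nc3Cl)c(N)n2)cc1` — 31800 nM

In a functional assay on HCT-116 cells (Homo sapiens) for cytotoxicity, read by MTT assay, with a stated time of 48 h (a lower number here means a stronger inhibitor, a higher number a weaker inhibitor), compound 1 returns only a limit of the assay, > 50000 nM. For the measured compounds named here, compound 2 gives 31800 nM in this assay, the only number in the set so far. The other value, that of compound 1, is a limit (the limit of > 50000 nM in this assay, at which 1 of the 2 values shown sits). Going by the values given here, the one measured step, an at least 1.5-fold lower number from compound 1 to compound 2 (0.19 log units; that floor lies within the scatter), is methoxy in place of methyl on an aromatic carbon, and its floor lies within the scatter, so it shows no change that can be trusted.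

Compound 3 `Nc1nc(-c2ccc(Br)cc2)cn1/N=C/c1cc2ccccc2nc1Cl` differs from compound 2 as follows: bromo in place of methoxy on an aromatic carbon. Among the compounds with values here, no measured step involves bromo, and the single step at this aromatic carbon was itself within the scatter; nothing therefore points to a shift in this assay beyond the scatter in either direction. Compound 3 is expected to sit near compound 2, with a 1.0-fold higher number from compound 2 to compound 3 (0.00 log units; within the scatter). Compound 3 is estimated at 32000 nM in this assay, within a range of 10000 nM to 100000 nM.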

Compound 3, half-maximal inhibitory concentration: > 50000 nM
Compound 3 ended at the assay's limit (the forecaster's own chance of this, stated with the estimate: 35%); at least 1.5-fold (0.19 log units) between middle value and limit.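

In this assay, bromo in place of methoxy on this aromatic carbon, para to a large group, gives an at least 1.5-fold higher number from compound 2 to compound 3 (0.19 log units; that floor lies within the scatter). Like the earlier step at this carbon, it fixes only a floor, so a second substituent change still shows no change that can be trusted. For the compounds shown here, the value of compound 3, > 50000 nM, is a limit of the assay, and most of the series now stands there: the limit of > 50000 nM in this assay, at which 2 of the 3 values shown sit. The step joining the two limit compounds cannot be read, so methyl and bromo cannot be ordered, and compound 2 remains the only compound with a number.

As far as these compounds go, how far the limit compounds lie from compound 2 remains open, and with it whether any change at this carbon exceeds the scatter. Also open, from the compounds shown here alone, is whether an amine or a carboxylic acid here would give a readable number in this assay.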